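Swapping the aryl group on the piperazine of a benzimidazole amide

This account rests on a few compounds, and the source may have more. Where it says the series, first, only, none or still open, it means among the compounds named here.

Three compounds share one core and differ only in the aromatic group on an amine nitrogen in a ring. Compound 1 `O=C(CN1CCN(c2ccccn2)CC1)Nc1nc2ccccc2[nH]1` gives 57.3% in a functional assay, read by spectrophotometry, with a stated time of 30 min, tested at 100 ug/mL; a lower number here means a weaker effect, a higher number a stronger effect of the compound at the concentration tested. Compound 2 `O=C(CN1CCN(c2ncccn2)CC1)Nc1nc2ccccc2[nH]1` gives 46.5%, a change of a number 10.8 percentage points lower from compound 1 to compound 2 (beyond the scatter). Compound 3 `O=C(CN1CCN(c2ccc([N+](=O)[O-])cc2)CC1)Nc1nc2ccccc2[nH]1` gives 51.7%; it stands close to both others, since a number 5.6 percentage points lower from compound 1 to compound 3 (within the scatter) and a number 5.2 percentage points higher from compound 2 to compound 3 (within the scatter) are each inside the usual scatter.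

Compound 4 `COc1ccccc1N1CCN(CC(=O)Nc2nc3ccccc3[nH]2)CC1` is not yet measured. It differs from compound 3 by 2-methoxyphenyl in place of 4-nitrophenyl on an amine nitrogen in a ring. Going by the values given here, the steps that bear on this change are the two that already replace or introduce the 4-nitrophenyl group, a number 5.6 percentage points lower from compound 1 to compound 3 (within the scatter) and a number 5.2 percentage points higher from compound 2 to compound 3 (within the scatter), both within the scatter, while the only step beyond the scatter, a number 10.8 percentage points lower from compound 1 to compound 2 (beyond the scatter), was modest. Among the compounds with values here, no measured compound carries 2-methoxyphenyl, so the direction is open. The step of a number 1.7 percentage points lower from compound 3 to compound 4 (within the scatter) is therefore expected to stay within or near the scatter. Compound 4 is expected to give 50%, with a range from 35% to 65%.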

Compound 4, a percentage reported as activity, at one concentration (the size of the read-out at that concentration, not a potency): 43.2%
Estimate against measurement, compound 4: 6.8 percentage points above; the measured number falls inside the stated range.
By their numbers in this assay, from the lowest: compounds 4, 2, 3 and 1 (each within the scatter of the next, the first and the last beyond it).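

With 2-methoxyphenyl on the amine nitrogen, the result adds a compound that this assay does not separate from its neighbours, at a number 8.5 percentage points lower from compound 3 to compound 4 (within the scatter) and a number 3.3 percentage points lower from compound 2 to compound 4 (within the scatter), so this group, 4-nitrophenyl and pyrimidin-2-yl cannot be told apart here. It also gives a second step beyond the scatter, the modest a number 14.1 percentage points lower from compound 1 to compound 4 (beyond the scatter), yet compound 3 stays within the scatter of both compound 1 and compound 4, so the values form a narrow continuous spread rather than two separate groups. Nothing available explains these differences.

Every group shown is an aromatic ring placed directly on the amine nitrogen, so what a benzyl group, an acetyl group or a simple methyl would give there remains open. So does the result for plain phenyl or 4-methoxyphenyl.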